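A few compounds are considered here, and "the series" means these few. Any claim that something is new, unique, unknown or untested is made for them only; others in the source may bear on it.

Working notes on the series, starting from compound 1 (`C[Si](C)(CNc1ccccc1)c1ccccc1`). For the measured compounds named here, in a functional assay on the whole organism for inhibition, with Homo sapiens as the target (a higher number here means a weaker inhibitor, a lower number a stronger inhibitor), compound 1 gives 7800 nM, the higher of the two numbers so far, while compound 2 (`COc1ccc(NC[Si](C)(C)c2ccccc2)cc1`) gives 3000 nM. Next in line is compound 3 (`CCN(C[Si](C)(C)c1ccccc1)c1ccccc1`), not yet measured. Its difference from compound 1 is ethyl in place of hydrogen on a nitrogen on an aromatic ring.

Going by the values given here, only one measured step bears on this change: a 2.6-fold lower number from compound 1 to compound 2 (0.41 log units; beyond the scatter), which comes with methoxy in place of hydrogen on an aromatic carbon. That step is modest and sits at a different place, so it offers a rough scale of size but no direction for a change on the nitrogen. Among the compounds with values here, no measured compound carries a substituent on that nitrogen. The expectation is therefore a step no larger than that modest one, and most likely none beyond the scatter, with either direction open. The estimated step is a 1.1-fold lower number from compound 1 to compound 3 (0.05 log units; within the scatter). In this assay the estimate for compound 3 is 7000 nM, with an expected range from 2200 nM to 22000 nM.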

Compound 3, half-maximal inhibitory concentration: 15000 nM
For compound 3 the middle estimate is 2.1-fold (0.33 log units) below the measured one; measured number inside the range.
By their numbers in this assay, from the lowest: compound 2; then compounds 1 and 3 (each within the scatter of the next).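

For the compounds shown here, on a nitrogen on an aromatic ring, ethyl in place of hydrogen gives the first reading at this position, and in this assay the change amounts to a 1.9-fold higher number from compound 1 to compound 3 (0.28 log units; within the scatter), a step within the scatter. The hydrogen on this nitrogen can therefore be replaced by ethyl, with 2 heavy atoms and no ring, without a step beyond the scatter, something the methoxy change on the aromatic carbon could not show. No measurement at hand bears on the reason for this result.

Going by these compounds, whether a methyl, a longer chain or an acetyl on this nitrogen would also stay within the scatter of compound 1 remains open, as does whether ethyl on the nitrogen and methoxy on the aromatic carbon would act independently when combined in one compound. One substituent at this position gives no trend with chain length, and an amine or a carboxylic acid at the end of such a chain would test a different kind of group altogether.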